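Swapping the 2-fluorophenyl group of compound 1

The source may hold more compounds than are shown below. What is called first, only, known or untested is meant among the compounds shown, and "the series" means these compounds.

compound 1 `COc1cc(/C=C2\CN(C)C/C(=C\c3ccccc3F)C2=O)cc(OC)c1` gives 5450 nM
compound 2 `COc1cc(/C=C2\CN(C)C/C(=C\c3ccccc3F)C2=O)cc(OC)c1OC` gives 3220 nM
compound 3 `CN1C/C(=C\c2ccc(C(F)(F)F)cc2)C(=O)/C(=C/c2ccccc2F)C1` gives 6560 nM

All three values come from a functional assay on HeLa cells (Homo sapiens) for cytotoxicity, read by MTT assay, with a stated time of 24 h (on this read-out lower numbers stand for stronger inhibition and higher numbers for weaker inhibition), and the gaps from compound 1 to the other two lie within the scatter, so compound 1 cannot be ranked against either of them.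

The next compound is compound 4 `COc1cc(/C=C2\CN(C)C/C(=C\c3ccc(Cl)c(Cl)c3)C2=O)cc(OC)c1` which keeps the core of compound 1 and differs from it by a single swap: 3,4-dichlorophenyl in place of 2-fluorophenyl on a double-bonded chain carbon bound to a double-bonded ring carbon and nothing else changes. Within the data shown here, the only measured single-change step is a 1.7-fold lower number from compound 1 to compound 2 (0.23 log units; within the scatter) and it concerns a methoxy group, not the group being replaced here. All three measured compounds carry the 2-fluorophenyl group, so no measurement shows what replacing it does. The data therefore support no step beyond the scatter and no firm direction. The expected step is a 1.2-fold lower number from compound 1 to compound 4 (0.08 log units; within the scatter) and this remains only an estimate. In this assay compound 4 is expected to give 4500 nM with 1500 nM to 13000 nM as the likely range.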

Compound 4, half-maximal inhibitory concentration: 6900 nM
Estimate against measurement, compound 4: 1.5-fold (0.19 log units) below, within the range that was stated.
By their numbers in this assay, from the lowest: compounds 2, 1, 3 and 4 (each within the scatter of the next, the first and the last beyond it).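

Among these compounds, this is the first measurement in which the 2-fluorophenyl group itself is replaced. In this assay the swap to 3,4-dichlorophenyl on a double-bonded chain carbon bound to a double-bonded ring carbon gives a 1.3-fold higher number from compound 1 to compound 4 (0.10 log units; within the scatter) and so no change can be claimed for it. This position therefore takes a phenyl ring with two chlorines in place of one with a single fluorine without any difference that can be told from the scatter, and no measured property of either group is available to explain that.

From the compounds shown here alone, whether a group of another kind at this place, such as an amine or a carboxylic acid, would move the number beyond the scatter stays open. Also open, going by these compounds, is whether the extra methoxy of compound 2 would read the same alongside 3,4-dichlorophenyl.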